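The source may hold more compounds than are shown below. What is called first, only, known or untested is meant among the compounds shown, and "the series" means these compounds.

Compound 1, with structure `N#Cc1ccc(Nc2nc(Oc3ccc(F)cc3)c3ccccc3n2)cc1`, bears a 4-fluorophenyl on the oxygen of the shared core. In an ADME assay on MT4 cells (Homo sapiens) for cytotoxicity, read by MTT assay, with a stated time of 4 days (a higher number here means that more compound is tolerated, a lower number that less compound is tolerated), compound 1 gives only a limit, > 351000 nM, at the limit of > 351000 nM in this assay, at which 1 of the 3 values shown sits. Compound 2 `Cc1cc(Br)c(Oc2nc(Nc3ccc(C#N)cc3)nc3ccccc23)c(Br)c1` carries a 2,6-dibromo-4-methylphenyl at the same place; in this assay compound 2 gives 25000 nM. Compound 3 `Cc1cc(C#N)cc(C)c1Oc1nc(Nc2ccc(C#N)cc2)nc2ccccc12` carries a 4-cyano-2,6-dimethylphenyl; in this assay compound 3 gives 203000 nM. Among the two numbers shown, compound 3 stands highest, with an 8.1-fold higher number from compound 2 to compound 3 (0.91 log units; beyond the scatter) as the step from its nearest neighbour. The other steps are an at least 14-fold lower number from compound 1 to compound 2 (1.14 log units; beyond the scatter) and an at least 1.7-fold lower number from compound 1 to compound 3 (0.23 log units; that floor lies within the scatter), the second resting on a limit.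

Compound 4 `Cc1ccccc1Oc1nc(Nc2ccc(C#N)cc2)nc2ccccc12` is the next step from compound 3: 2-methylphenyl in place of 4-cyano-2,6-dimethylphenyl on an oxygen on an aromatic ring. All three measured steps change the aryl on this oxygen, and the smallest aryl, in compound 1, sits at the limit while the dibromo aryl of compound 2 gives the lowest number. A smaller aryl in compound 4 is therefore expected to give a number no lower than that of compound 3, with a step of a 1.5-fold higher number from compound 3 to compound 4 (0.17 log units; within the scatter) that may not pass the scatter. The estimate for compound 4 in this assay is 300000 nM, within 100000 nM to 900000 nM, with a fair chance that only a limit is reported.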

Compound 4, half-maximal cytotoxic concentration: 355000 nM
Beside the measured number, compound 4's estimate is 1.2-fold (0.07 log units) below it; low and high end bracket the measured number.
By their numbers in this assay, from the lowest: compound 2; then compounds 3 and 4 (each within the scatter of the next).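

With the smaller 2-methylphenyl, which carries no nitrile, the number in this assay does not separate from that of the 4-cyano-2,6-dimethylphenyl compound: a 1.7-fold higher number from compound 3 to compound 4 (0.24 log units; within the scatter). Loss of the nitrile together with one methyl therefore leaves the reading within the scatter at this oxygen, so the nitrile on this aryl is not needed for a number of this order. For the compounds shown here, the change from the dibromo aryl is much clearer, with a 14-fold higher number from compound 2 to compound 4 (1.15 log units; beyond the scatter), and this leaves compound 2 as the one compound in the readable set that stands apart from the others. The step from compound 1 to compound 4 cannot be read, as compound 1 gives only a limit: the limit of > 351000 nM in this assay, at which 1 of the 4 values shown sits.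

The compounds shown do not tell whether the low number of compound 2 follows its two bromine atoms or the full 2,6-dibromo-4-methylphenyl group, and a phenyl bearing a single bromine or a chlorine would separate these readings. On these data alone, how an amine or a carboxylic acid on this aryl would move the number in this assay also remains open.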